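Shifting the Chlorine: From Compound 3 to Compound 4

The source may report more compounds than this note shows. Statements on the series, on what has been measured and on what is new or still open speak of the compounds shown alone.

Compound 1, `COC(=O)c1ccc(-c2nnc(SC3=CS(=O)(=O)c4ccccc43)o2)cc1`: 4000 nM
Compound 2, `CC(=O)Nc1ccc(-c2nnc(SC3=CS(=O)(=O)c4ccccc43)o2)cc1`: 4000 nM
Compound 3, `O=S1(=O)C=C(Sc2nnc(-c3ccc(Cl)cc3)o2)c2ccccc21`: 3000 nM

These three compounds share one core and were tested in an ADME assay on HEK293 cells (Homo sapiens) for cytotoxicity, read by fluorescence and resazurin assay, with a stated time of 24 h; on this read-out higher numbers stand for lower toxicity in this test and lower numbers for higher toxicity in this test. Compound 3 gives the lowest of the three numbers, but the step of a 1.3-fold lower number from compound 1 to compound 3 (0.12 log units; within the scatter) and the step of a 1.3-fold lower number from compound 2 to compound 3 (0.12 log units; within the scatter) both lie within the scatter, as does the step of no change at the digits printed from compound 1 to compound 2 (within the scatter), so on this read-out the three cannot be told apart.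

Compound 4, `O=S1(=O)C=C(Sc2nnc(-c3cccc(Cl)c3)o2)c2ccccc21`, has not yet been measured. It differs from compound 3 in a single place: 3-chlorophenyl in place of 4-chlorophenyl on an aromatic carbon. Among the compounds with values here, the measured steps all exchanged one group for a different one on the phenyl ring; none of them compared a 3-chlorophenyl with a 4-chlorophenyl, so no step bears directly on this change. Since exchanging methoxycarbonyl, acetamido and chloro left every number within the scatter, a change that keeps the same chlorine and the same ring is expected to do no more. Compound 4 is therefore expected to give about 3000 nM in this assay, within a range from 1500 nM to 6000 nM. The expected step is no change at the digits printed from compound 3 to compound 4 (within the scatter), meaning no change beyond the scatter.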

Compound 4, half-maximal cytotoxic concentration: 6000 nM
Estimate against measurement, compound 4: 2.0-fold (0.30 log units) below, and the stated range covers the measured number.
By their numbers in this assay, from the lowest: compounds 3, 1, 2 and 4 (each within the scatter of the next).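

Compound 4 has the same atoms as compound 3, joined differently, so this pair isolates something the earlier exchanges of one group for another could not: where the chlorine sits on the phenyl ring, with 3-chlorophenyl in place of 4-chlorophenyl. In this assay the result is a 2.0-fold higher number from compound 3 to compound 4 (0.30 log units; within the scatter) and so, although this is the largest step among the compounds shown, compound 3 and compound 4 cannot be told apart on this read-out. Moving the chlorine therefore joins the exchanges of methoxycarbonyl, acetamido and chloro as a change that stays within the scatter, and no supporting measurement is available that could explain the size of this step.

On these data alone, all four compounds keep the shared core and differ only in the phenyl group, so it remains open whether an amine or a carboxylic acid on that ring, or a longer chain in place of the chlorine, would produce a step beyond the scatter. It also remains open whether an amine placed on the shared core itself would leave the number as unmoved as the changes shown here.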